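The source may hold more compounds than are shown below. What is called first, only, known or untested is meant among the compounds shown, and "the series" means these compounds.

Two compounds of the series have been run in a functional assay on M21 cells (Homo sapiens) for antiproliferative activity, read by sulforhodamine B assay, with a stated time of 48 h; a lower number here means a stronger inhibitor, a higher number a weaker inhibitor. Compound 1 `CCC(=O)Nc1ccc(S(=O)(=O)Oc2ccccc2I)cc1` gives 11000 nM in this assay. Compound 2 `CCCCCC(=O)Nc1ccc(S(=O)(=O)Oc2ccccc2C(C)C)cc1` gives 6700 nM in this assay, the lowest of the two numbers; compound 1 is its nearest neighbour, and the gap between the two values lies within the scatter, so no order between them can be read. Within the data shown here, compound 1 and compound 2 differ in two places at once, so no single step between measured compounds is available.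

Compound 3 `CCCCCC(=O)Nc1ccc(S(=O)(=O)Oc2ccccc2I)cc1` has not yet been measured in this assay. It is related to compound 2 by one change, (iodo in place of isopropyl on an aromatic carbon), on an aromatic carbon of a six-membered aromatic ring of carbon only, ortho to a large group. Among the measured compounds shown here, the iodo group is the one carried by compound 1, and the amide chain is that of compound 2. Compound 1 with 11000 nM and compound 2 with 6700 nM sit within the scatter of each other, and on that basis the expected step from this change is a 1.2-fold higher number from compound 2 to compound 3 (0.08 log units; within the scatter), none beyond the scatter in either direction. Compound 3 is therefore expected to give about 8000 nM in this assay, within a range from 3000 nM to 20000 nM.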

Compound 3, half-maximal inhibitory concentration: 11000 nM
For compound 3 the middle estimate is 1.4-fold (0.14 log units) below the measured one; the measured number falls inside the stated range.
By their numbers in this assay, from the lowest: compounds 2, 1 and 3 (each within the scatter of the next).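

In this assay, among these compounds, the first single-place comparison at this aromatic carbon, ortho to a large group, gives a 1.6-fold higher number from compound 2 to compound 3 (0.22 log units; within the scatter) for iodo in place of isopropyl, so a single iodine atom and a branched group of three carbons cannot be told apart on this read-out. The second single-place comparison, on the saturated chain two bonds along from the carbonyl carbon, gives no change at the digits printed from compound 1 to compound 3 (within the scatter) for propyl in place of hydrogen, so the two amide chains cannot be told apart either, at least with iodo on the ring. No measurement bears on why neither replacement produces a step beyond the scatter.

It remains open whether the amide chains would also read alike with isopropyl on the ring, since the pairing of the shorter chain with isopropyl is not among the compounds shown. On these data alone, it is equally open whether an amine or a carboxylic acid at this aromatic carbon, or a longer chain on the amide, would move this assay beyond the scatter, since the groups compared so far are only iodo and isopropyl on the ring and two chain lengths.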